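The compounds below may be only part of what the source reports. "The series", "measured", "known", "first", "only" and "open" are said of these compounds alone.

Three compounds have so far been measured in a functional assay on HeLa cells (Homo sapiens) for cytotoxicity, read by WST assay, with a stated time of 48 h; on this read-out lower numbers stand for stronger inhibition and higher numbers for weaker inhibition:
compound 1, `COc1ccc(/C=C/C[C@H]2C[C@@H]([C@@H](O)c3ccccc3)CO[C@@H]2c2ccccc2)cc1`, gives 8300 nM;
compound 2, `Oc1cccc(/C=C/C[C@H]2C[C@@H]([C@@H](O)c3ccccc3)CO[C@@H]2c2ccccc2)c1`, gives 18600 nM;
compound 3, `COc1cccc(/C=C/C[C@H]2C[C@@H]([C@@H](O)c3ccccc3)CO[C@@H]2c2ccccc2)c1`, gives 10900 nM.

Among these three numbers compound 3 stands second highest. Its nearest neighbour is compound 1, separated by a 1.3-fold higher number from compound 1 to compound 3 (0.12 log units; within the scatter); the furthest is compound 2, separated by a 1.7-fold lower number from compound 2 to compound 3 (0.23 log units; within the scatter). Going by the values given here, the only step among the measured compounds that reaches beyond the scatter is a 2.2-fold higher number from compound 1 to compound 2 (0.35 log units; beyond the scatter), and that step is modest.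

Compound 4, `O=[N+]([O-])c1ccccc1/C=C/C[C@H]1C[C@@H]([C@@H](O)c2ccccc2)CO[C@@H]1c1ccccc1`, differs from compound 3 in one place: 2-nitrophenyl in place of 3-methoxyphenyl on a double-bonded chain carbon bound to a double-bonded chain carbon. Every measured step alters the same aromatic group on the same double-bonded chain carbon, and none of them moves the number far: the largest, a 2.2-fold higher number from compound 1 to compound 2 (0.35 log units; beyond the scatter), is modest, while a 1.3-fold higher number from compound 1 to compound 3 (0.12 log units; within the scatter) and a 1.7-fold lower number from compound 2 to compound 3 (0.23 log units; within the scatter) both lie within the scatter. Among the compounds with values here, the 2-nitrophenyl group has no precedent among the measured compounds, so the direction of its effect cannot be read from them. For compound 4 the expected step in this assay is therefore a 1.0-fold higher number from compound 3 to compound 4 (0.00 log units; within the scatter), none beyond the scatter. Compound 4 is estimated at 11000 nM, with a range from 4000 nM to 30000 nM.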

Compound 4, half-maximal inhibitory concentration: 11800 nM
Compound 4: middle estimate off by 1.1-fold (0.03 log units), on the low side, and the stated range covers the measured number.
By their numbers in this assay, from the lowest: compounds 1, 3, 4 and 2 (each within the scatter of the next, the first and the last beyond it).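

In this assay, the 2-nitrophenyl group sits on a double-bonded chain carbon bound to a double-bonded chain carbon and gives a number within the scatter of all three earlier compounds: there is a 1.1-fold higher number from compound 3 to compound 4 (0.03 log units; within the scatter) and a 1.6-fold lower number from compound 2 to compound 4 (0.20 log units; within the scatter) and also a 1.4-fold higher number from compound 1 to compound 4 (0.15 log units; within the scatter) in this series. The earlier steps shown here had only exchanged hydroxyl and methoxy phenyl groups, so this result extends the same flat picture to a group with a nitrogen, more heavy atoms and a double bond outside the aromatic ring, and compound 4 does not widen the span set by compound 1 and compound 2. Nothing available explains why this exchange leaves the number where it is.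

Compound 4 alone carries a nitro group, so these compounds cannot separate the effect of that group from the effect of its place on the ring. They also leave open whether this position stays as flat with an amine or a carboxylic acid on the phenyl ring, or with a longer chain in place of the ring.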